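Solubility notes on three measured compounds and one pending

A few compounds are considered here, and "the series" means these few. Any claim that something is new, unique, unknown or untested is made for them only; others in the source may bear on it.

Measured so far:
Compound 1 `CC(C)c1ccc2c(c1)[n+]([O-])c(NCCN(C)C)n[n+]2[O-]` — in a physicochemical assay for solubility, in the presence of a further agent that is not named here (a higher number here means a more soluble compound, a lower number a less soluble compound), compound 1 gives 42000000 nM.
Compound 2 `CC(C)c1ccc2c(c1)[n+]([O-])c(NCCN1CCCCC1)n[n+]2[O-]` — in this assay compound 2 gives 18000000 nM.
Compound 3 `COc1ccc2c(c1)[n+]([O-])c(NCCN(C)C)n[n+]2[O-]` — in this assay compound 3 gives 46000000 nM.

Two changes are seen within the measured set. The first, (piperidin-1-yl in place of dimethylamino on a saturated chain carbon, two bonds along the chain from a nitrogen on an aromatic ring), produced a 2.3-fold lower number from compound 1 to compound 2 (0.37 log units; beyond the scatter). The second, (methoxy in place of isopropyl on an aromatic carbon), produced a 1.1-fold higher number from compound 1 to compound 3 (0.04 log units; within the scatter), so the two cores of compound 1 and compound 3 cannot be separated in this assay on these numbers.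

Compound 4 `COc1ccc2c(c1)[n+]([O-])c(NCCN1CCCCC1)n[n+]2[O-]` is not yet measured. It differs from compound 3 by piperidin-1-yl in place of dimethylamino on a saturated chain carbon, two bonds along the chain from a nitrogen on an aromatic ring, and the place of this change is the same, word for word, as the place of the change from compound 1 to compound 2; it is therefore the same change made on the core of compound 3 instead of the core of compound 1.

Compound 4 is expected to give about 20000000 nM in this assay, within a range from 10000000 nM to 40000000 nM. Among the compounds with values here, this expectation corresponds to an estimated step of a 2.3-fold lower number from compound 3 to compound 4 (0.36 log units; beyond the scatter), and rests on the single earlier step of a 2.3-fold lower number from compound 1 to compound 2 (0.37 log units; beyond the scatter) made by the same change, with no second example to confirm it.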

Compound 4, solubility: 45000000 nM
Compound 4: middle estimate off by 2.3-fold (0.35 log units), on the low side; the measured number lies above the stated range.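

In this assay, piperidin-1-yl in place of dimethylamino gives a 1.0-fold lower number from compound 3 to compound 4 (0.01 log units; within the scatter), whereas the same change on the core of compound 1 gave a 2.3-fold lower number from compound 1 to compound 2 (0.37 log units; beyond the scatter), so the step did not carry from one core to the other. Seen the other way, methoxy in place of isopropyl gives a 1.1-fold higher number from compound 1 to compound 3 (0.04 log units; within the scatter) with dimethylamino on the chain but a 2.5-fold higher number from compound 2 to compound 4 (0.40 log units; beyond the scatter) with piperidin-1-yl, so in these four compounds the two changes do not simply add. This rests on one pair per core and does not show how the change behaves on any other core, and nothing available explains the difference between the two cores.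

Open, on these data alone, is whether a pyrrolidin-1-yl or morpholin-4-yl group in place of dimethylamino would follow the pattern of the core of compound 1 or that of the core of compound 3. Also open, as far as these compounds go, is what a longer chain, or an ethoxy or chloro group in place of methoxy, would do to the piperidin-1-yl step.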